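This account rests on a few compounds, and the source may have more. Where it says the series, first, only, none or still open, it means among the compounds named here.

Values measured in an ADME assay on microsomes from liver (Rattus norvegicus) for metabolic stability, read by LC-MS, using NADPH, with a stated time of 30 min, tested at 1 uM; a higher number here means faster removal of the compound, a lower number slower removal:

- compound 1 `Cc1cc2c(cn1)Oc1ccc(NC(=O)c3ccc(Cl)cn3)cc1[C@@]21COC(N)=N1`: < 14 mL.min-1.g-1 (a limit)
- compound 2 `NC1=N[C@@]2(CO1)c1cc(-c3cncc(C#CC4CC4)c3)ccc1Oc1cnc(C3=CCOCC3)cc12`: 23 mL.min-1.g-1
- compound 3 `CC#Cc1cncc(-c2ccc3c(c2)[C@@]2(COC(N)=N2)c2cc(C4=CCCOC4)ncc2O3)c1`: 45 mL.min-1.g-1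

Compound 1 is reported only as a limit, < 14 mL.min-1.g-1. Of the two compounds with actual numbers, compound 2 gives 23 mL.min-1.g-1 and compound 3 gives 45 mL.min-1.g-1, and these values lie within the usual scatter of each other.

Compound 4 `CC1(C#Cc2cncc(-c3ccc4c(c3)[C@@]3(COC(N)=N3)c3cc(C5=CCOCC5)ncc3O4)c2)COC1` has not yet been measured. It carries 3-methyloxetan-3-yl in place of cyclopropyl on a triple-bonded carbon, and its difference from compound 2 is 3-methyloxetan-3-yl in place of cyclopropyl on a triple-bonded carbon. Going by the values given here, no pair of measured compounds differs in one place only, so the data offer no direct guide to the size of this change in this assay. A small shift towards slower removal is expected, one that stays within the scatter, starting from the 23 mL.min-1.g-1 of compound 2. The expected step is a 1.3-fold lower number from compound 2 to compound 4 (0.11 log units; within the scatter). For compound 4 the estimated value is 18 mL.min-1.g-1, with an expected range of 10 mL.min-1.g-1 to 35 mL.min-1.g-1.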

Compound 4, intrinsic clearance in microsomes: 73 mL.min-1.g-1
Estimate against measurement, compound 4: 4.1-fold (0.61 log units) below, and the stated range ends below it.
By their numbers in this assay, from the lowest: compounds 2, 3 and 4 (each within the scatter of the next, the first and the last beyond it). At a limit, below all of these: compound 1.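

In this assay, going by these compounds alone, the change from cyclopropyl to 3-methyloxetan-3-yl on a triple-bonded carbon gives a 3.2-fold higher number from compound 2 to compound 4 (0.50 log units; beyond the scatter), the only single-place step in this set, and it lies beyond the scatter. It shows that the group on this triple-bonded carbon can alter the rate of removal, and that in this one pair, the group with more heavy atoms and a ring oxygen goes with the faster removal. Nothing measured here accounts for the direction or size of this step.

The compounds shown leave open whether the ring oxygen, the methyl or the larger ring goes with the step. A 1-methylcyclobutyl group or an unsubstituted oxetan-3-yl group on the same carbon would separate these parts.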